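A few compounds are considered here, and "the series" means these few. Any claim that something is new, unique, unknown or untested is made for them only; others in the source may bear on it.

Measured so far in an ADME assay on microsomes from liver (Homo sapiens) for metabolic stability, read by LC-MS, with a stated time of 30 min, tested at 0.1 uM; a higher number here means that more of the compound is left, a lower number that less of the compound is left:
compound 1 `FC(F)(F)Oc1ccc(-c2nc3cnc(Nc4ccccn4)cc3[nH]2)cc1`: 60%
compound 2 `FC(F)(F)c1cccc(-c2nc3cnc(Nc4ccncn4)cc3[nH]2)c1`: 90%

Compound 2 stands highest of these two, and the gap down to compound 1 lies beyond the usual scatter. Compound 3 `FC(F)(F)c1ccc(Nc2cc3[nH]c(-c4cccc(C(F)(F)F)c4)nc3cn2)nc1` differs from compound 2 in one place 5-(trifluoromethyl)pyridin-2-yl in place of pyrimidin-4-yl on a nitrogen on an aromatic ring: 5-(trifluoromethyl)pyridin-2-yl stands in place of pyrimidin-4-yl on a nitrogen on an aromatic ring. Going by the values given here, no measured pair shows this change, so any forecast is uncertain. Compound 2 gives 90%, which leaves little room upward. A moderate downward change in this assay is expected, an estimated step of a number 15 percentage points lower from compound 2 to compound 3 (beyond the scatter). For compound 3 the expected value is 75%, with an estimated range of 55% to 93%.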

Compound 3, percent of the compound remaining: 90%
Compound 3: middle estimate off by 15 percentage points, on the low side, within the range that was stated.
By their numbers in this assay, from the lowest: compound 1; then compounds 2 and 3 (each within the scatter of the next).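

Placing 5-(trifluoromethyl)pyridin-2-yl in place of pyrimidin-4-yl on this nitrogen gives no change at the digits printed from compound 2 to compound 3 (within the scatter) in this assay and so shows that this position can carry the larger ring with its trifluoromethyl group without a step beyond the scatter. This holds only for this one pair, with the rest of the structure kept as in compound 2. No measurement at hand offers a reason for this result.

Still open, going by these compounds, is how a plain phenyl ring, or a pyridine ring carrying an amine or a methyl group instead of trifluoromethyl, would read at this nitrogen.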